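Extending a sulfonyl chain on a shared core

A few compounds are considered here, and "the series" means these few. Any claim that something is new, unique, unknown or untested is made for them only; others in the source may bear on it.

Of the compounds shown here, three have been measured in a functional assay (aorta) with Oryctolagus cuniculus as the target; a higher number here means a weaker inhibitor, a lower number a stronger inhibitor: compound 1 `CCCCc1cnc(-c2nn(Cc3ccccc3F)c3ncccc23)nc1N` gives 218000 nM, compound 2 `CCCCCCc1cnc(-c2nn(Cc3ccccc3F)c3ncccc23)nc1N` gives 1040000 nM, and compound 3 `CS(=O)(=O)c1cnc(-c2nn(Cc3ccccc3F)c3ncccc23)nc1N` gives 261000 nM.

Compound 2 differs from compound 1 by ethyl in place of hydrogen on a saturated chain carbon, four bonds along the chain from an aromatic carbon, and this change made a step of a 4.8-fold higher number from compound 1 to compound 2 (0.68 log units; beyond the scatter). Compound 3 differs from compound 1 by methylsulfonyl in place of butyl on an aromatic carbon, a change that gave a 1.2-fold higher number from compound 1 to compound 3 (0.08 log units; within the scatter). Compound 4 `CCCS(=O)(=O)c1cnc(-c2nn(Cc3ccccc3F)c3ncccc23)nc1N` differs from compound 3 by ethyl in place of hydrogen on a saturated chain carbon bound to a sulfonyl sulfur. This is the same kind of change as from compound 1 to compound 2, but not the same: there the new ethyl sits four bonds along the chain from an aromatic carbon, here it sits bound to a sulfonyl sulfur. A weakening step is expected, a 2.5-fold higher number from compound 3 to compound 4 (0.40 log units; beyond the scatter), resting on the step of a 4.8-fold higher number from compound 1 to compound 2 (0.68 log units; beyond the scatter) seen in this assay and softened for the different surroundings. Compound 4 is expected to give 650000 nM, in the range 250000 nM to 2000000 nM.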

Compound 4, half-maximal inhibitory concentration: 378000 nM
Estimate against measurement, compound 4: 1.7-fold (0.24 log units) above; the measured number falls inside the stated range.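

The same ethyl addition does not carry over at the same size from one chain to the other: the same change on two cores in this assay, a 4.8-fold higher number (0.68 log units; beyond the scatter) from compound 1 to compound 2 and a 1.4-fold higher number (0.16 log units; within the scatter) from compound 3 to compound 4, 3.3-fold (0.52 log units) apart, beyond the scatter of two such steps On the sulfonyl chain in this assay, the step of a 1.4-fold higher number from compound 3 to compound 4 (0.16 log units; within the scatter) is no real change, and propylsulfonyl in place of butyl also stays level, with a 1.7-fold higher number from compound 1 to compound 4 (0.24 log units; within the scatter), while propylsulfonyl in place of hexyl gives a 2.8-fold lower number from compound 2 to compound 4 (0.44 log units; beyond the scatter). Among these compounds, with only one pair on each side, this does not show why the two steps differ or how the change would behave on any other compound.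

Still open, on these data alone, is whether a longer sulfonyl chain, such as hexylsulfonyl, would stay level with compound 3 or give a clearly higher number. As far as these compounds go, how an amine or a carboxylic acid would read on that same aromatic carbon is also open.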